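Hydroxy entering the aromatic ring: toward compound 4

A few compounds are considered here, and "the series" means these few. Any claim that something is new, unique, unknown or untested is made for them only; others in the source may bear on it.

Measured compounds:
compound 1 `CC1=CC[C@H](C(C)(C)NC(=S)N/N=C/c2ccccc2)CC1` — 22200 nM
compound 2 `COc1ccc(/C=N/NC(=S)NC(C)(C)[C@H]2CC=C(C)CC2)cc1` — 33600 nM
compound 3 `CC1=CC[C@H](C(C)(C)NC(=S)N/N=C/c2ccc(O)cc2)CC1` — > 100000 nM, a limit

In a functional assay on HT-29 cells (Homo sapiens) for inhibition, read by sulforhodamine B assay, with a stated time of 48 h (on this read-out higher numbers stand for weaker inhibition of growth and lower numbers for stronger inhibition of growth), compound 1 gives 22200 nM and stands lowest of the two numbers shown; compound 2, with a methoxy in place of hydrogen on an aromatic carbon, gives 33600 nM, and the step of a 1.5-fold higher number from compound 1 to compound 2 (0.18 log units; within the scatter) stays within the scatter. For compound 3 this assay reports only a limit, > 100000 nM (the limit of > 100000 nM in this assay, at which 1 of the 3 values shown sits). The steps of an at least 4.5-fold higher number from compound 1 to compound 3 (0.65 log units; beyond the scatter) and an at least 2.9-fold higher number from compound 2 to compound 3 (0.47 log units; beyond the scatter) are therefore both beyond the scatter, and both point toward weaker growth inhibition once a hydroxy sits on the ring.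

Compound 4 `CC1=CC[C@H](C(C)(C)NC(=S)N/N=C/c2ccccc2O)CC1` differs from compound 1 by hydroxy in place of hydrogen on an aromatic carbon. Among the measured compounds shown here, the closest measured step is the one from compound 1 to compound 3, which also introduces a hydroxy on an aromatic carbon of the shared core; the methoxy step from compound 1 to compound 2 bears on it only indirectly. With a hydroxy entering the ring again, a higher number than for compound 1 is expected, though a single measured hydroxy step cannot fix its size. Compound 4 is estimated at 50000 nM, in the range 20000 nM to 150000 nM, which means an expected step of a 2.3-fold higher number from compound 1 to compound 4 (0.35 log units; beyond the scatter), and a limit cannot be ruled out.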

Compound 4, concentration for total growth inhibition: 16600 nM
Compound 4: middle estimate off by 3.0-fold (0.48 log units), on the high side, outside the stated range (below it).
By their numbers in this assay, from the lowest: compounds 4, 1 and 2 (each within the scatter of the next, the first and the last beyond it). At a limit, above all of these: compound 3.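

In this assay, the step of a 1.3-fold lower number from compound 1 to compound 4 (0.13 log units; within the scatter) stays within the scatter, so phenyl to 2-hydroxyphenyl, with the hydroxy ortho to a large group, leaves the read-out where compound 1 stands, and a hydroxy on the aromatic ring does not by itself go with the loss seen for compound 3. The place of the hydroxy separates the two hydroxy compounds, as an at least 6.0-fold lower number from compound 3 to compound 4 (0.77 log units; beyond the scatter) lies beyond the scatter, while a 2.0-fold lower number from compound 2 to compound 4 (0.31 log units; beyond the scatter) is a modest step, also beyond the scatter, that changes the group's place and its identity together. Compound 3 remains a limit and not a number, so the true size of its step is unknown: the limit of > 100000 nM in this assay, at which 1 of the 4 values shown sits.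

Whether the tolerance for hydroxy ortho to a large group extends to other groups stays open, since an amine, a carboxylic acid or a methoxy in that place is not among the compounds shown. The compounds shown also leave open whether 2-hydroxyphenyl behaves the same way on a core other than the shared core, as the ring substituents here all sit on a single core.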